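Cytotoxicity limits across a four-compound series

A few compounds are considered here, and "the series" means these few. Any claim that something is new, unique, unknown or untested is made for them only; others in the source may bear on it.

Of the compounds shown here, three have been measured in an ADME assay on MT4 cells (Homo sapiens) for cytotoxicity, read by MTT assay, with a stated time of 96 h; a higher number here means that more compound is tolerated, a lower number that less compound is tolerated. Compound 1 `Brc1ccc(NCc2cn(-c3ccccc3)nc2-c2ccccc2)cc1` gives > 100000 nM, a limit of the assay rather than a number. Compound 2 `Cc1ccc(-c2nn(-c3ccccc3)cc2CNc2ccc(Br)cc2)cc1` gives > 100000 nM, again a limit. Compound 3 `Cc1ccc(NCc2cn(-c3ccccc3)nc2-c2ccc(Br)cc2)cc1` gives > 100000 nM, also a limit. The change from compound 2 to compound 1 is hydrogen in place of methyl on an aromatic carbon and its step, a step that the two limits leave unreadable from compound 2 to compound 1, cannot be read because of the limit of > 100000 nM in this assay, at which 3 of the 3 values shown sit. Compound 4 `Brc1ccc(-c2nn(-c3ccccc3)cc2CNc2ccccc2)cc1` differs from compound 3 by hydrogen in place of methyl on an aromatic carbon, the same change at the same kind of place; the difference between the cores of compound 3 and compound 2 is not broken down here. The expectation for compound 4 rests on compound 3 sitting at a limit and on the earlier step being unreadable. For compound 4 the expected step is a number no higher from compound 3 to compound 4 (the limit leaves the size open). The estimate for compound 4 in this assay is 100000 nM.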

Compound 4, half-maximal cytotoxic concentration: > 100000 nM
Compound 4: no number, only a limit; the forecaster's own chance of this, stated with the estimate: 90%; the middle value lies on the limit itself.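

No new step can be read between compound 3 and compound 4 in this assay, as both results are limits rather than numbers: the limit of > 100000 nM in this assay, at which 4 of the 4 values shown sit.

The compounds shown leave open where the half-maximal cytotoxic concentration of any of them lies and whether hydrogen in place of methyl on an aromatic carbon alters it.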